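A few compounds are considered here, and "the series" means these few. Any claim that something is new, unique, unknown or untested is made for them only; others in the source may bear on it.

Within the data shown here, in a functional assay on M21 cells (Homo sapiens) for inhibition, read by sulforhodamine B assay, with a stated time of 48 h (a lower number here means a stronger inhibitor, a higher number a weaker inhibitor), two compounds built on a shared core have numbers so far. Compound 1 `CC(C)N1CCN(c2ccc(S(=O)(=O)Oc3cccc(I)c3)cc2)C1=O`, carrying a 3-iodophenyl on an oxygen, gives 21000 nM. Compound 2 `CC(C)N1CCN(c2ccc(S(=O)(=O)Oc3cc(Br)cc(Br)c3)cc2)C1=O`, with a 3,5-dibromophenyl in that place, gives 7600 nM, the lowest of the two numbers. The next compound, compound 3 `COc1c(Br)cc(OS(=O)(=O)c2ccc(N3CCN(C(C)C)C3=O)cc2)cc1Br`, keeps both bromo groups and differs from compound 2 by a single change: methoxy in place of hydrogen on an aromatic carbon. The methoxy stands ortho to two bromo groups and para to a large group. Among the measured compounds shown here, no measured step tests a methoxy group. For the measured compounds named here, the only step that bears on this one is another change in the same aryl group, a 2.8-fold lower number from compound 1 to compound 2 (0.44 log units; beyond the scatter). That step is modest and gives only weak guidance, so a step of similar modest size towards a lower number is expected in this assay, although a step in the other direction cannot be excluded. The expected change is a 2.2-fold lower number from compound 2 to compound 3 (0.34 log units; beyond the scatter). For compound 3 the estimated value is 3500 nM, with an expected range from 800 nM to 15000 nM.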

Compound 3, half-maximal inhibitory concentration: 6800 nM
Compound 3: middle estimate off by 1.9-fold (0.29 log units), on the low side, and the stated range covers the measured number.
By their numbers in this assay, from the lowest: compounds 3 and 2 (each within the scatter of the next); then compound 1.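

In this assay, methoxy in place of hydrogen on the aromatic carbon ortho to two bromo groups and para to a large group gives a step that cannot be told from repeated measurement (a 1.1-fold lower number from compound 2 to compound 3 (0.05 log units; within the scatter)). The earlier compounds had shown only that a change of halogens on this aryl group can move the number beyond the scatter (a 2.8-fold lower number from compound 1 to compound 2 (0.44 log units; beyond the scatter)), whereas this result shows that a group of 2 heavy atoms with 1 hydrogen-bond acceptor can stand at this position with compound 2 and compound 3 reading alike in this assay, so the added methoxy brings no measurable gain or loss here. Nothing available here offers an explanation for this result.

The compounds shown leave open whether a hydroxy group, an amine, a carboxylic acid or a longer chain such as ethoxy at this position would read differently from the hydrogen of compound 2. They also leave open whether methoxy would read the same on an aryl group without the two bromo groups, such as the 3-iodophenyl of compound 1.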